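The source may hold more compounds than are shown below. What is called first, only, known or untested is meant among the compounds shown, and "the series" means these compounds.

Of the compounds shown here, three have so far been measured in an ADME assay on MCF-10A cells (Homo sapiens) for cytotoxicity, read by MTT assay, with a stated time of 72 h; a higher number here means a weaker inhibitor of growth, a lower number a stronger inhibitor of growth. Compound 1 `CS/C(=N\C(=O)c1sccc1Cl)NC(=O)c1sccc1Cl` gives 23700 nM, the lowest of the three numbers. Compound 2 `C[Se]/C(=N\C(=O)c1ccco1)NC(=O)c1ccco1` gives 40200 nM, a value that lies within the usual scatter of the number for compound 1, so these two cannot be placed in order. Compound 3 `CS/C(=N\C(=O)c1cccs1)NC(=O)c1cccs1` gives 55100 nM, and its gap from compound 1 lies beyond the scatter, so compound 3 is the weaker inhibitor of growth of that pair.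

Compound 4 `C[Se]/C(=N\C(=O)c1sccc1Cl)NC(=O)c1sccc1Cl` has not yet been measured. It differs from compound 1 in a single place: a group of 2 heavy atoms (1 carbon, 1 selenium; no ring) in place of a group of 2 heavy atoms (1 carbon, 1 sulfur; no ring), on a carbon with a double bond to nitrogen. Among the compounds with values here, no two measured compounds differ by this swap alone. Compound 2 and compound 3 carry the selenium and sulfur groups on different ring parts, so their values cannot be read as this step. The step is expected to be small, a 1.2-fold lower number from compound 1 to compound 4 (0.07 log units; within the scatter), in no direction beyond the scatter. Compound 4 is therefore expected to give about 20000 nM, with a range from 8000 nM to 50000 nM.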

Compound 4, concentration for total growth inhibition: 5490 nM
Compound 4: the middle estimate sits 3.6-fold (0.56 log units) above what was measured, and the stated range ends above it.
By their numbers in this assay, from the lowest: compound 4; then compounds 1, 2 and 3 (each within the scatter of the next, the first and the last beyond it).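

Within the core of compound 1, replacing methylsulfanyl with the selenium group on the carbon with a double bond to nitrogen gives a 4.3-fold lower number from compound 1 to compound 4 (0.64 log units; beyond the scatter) in this assay for this pair. This is the only pair shown in which the selenium-for-sulfur change stands alone, and it shows that this one atom at this position can move the number beyond the scatter. No measurement at hand accounts for the size or direction of the step.

As far as these compounds go, whether the same swap would give a similar step with other ring parts stays open, since compound 2 and compound 3 differ in more than one place. Also open, from the compounds shown here alone, is whether an ethyl chain on the selenium, or an amine at this carbon, would keep the lower number of compound 4 in this assay or lose it.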